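From chloro to cyano: what three compounds suggest

The compounds below may be only part of what the source reports. "The series", "measured", "known", "first", "only" and "open" are said of these compounds alone.

- compound 1 `O=C1c2ccc(Cl)cc2CN1c1cccnc1`: 76.5 mL/min/kg
- compound 2 `CCC1c2cc(Cl)ccc2C(=O)N1c1cccnc1`: 65.9 mL/min/kg
- compound 3 `CC1c2cc(Cl)ccc2C(=O)N1c1cccnc1`: 66.5 mL/min/kg

All three values come from an ADME assay on microsomes from liver (Mus musculus) for metabolic stability, read by LC-MS, using NADPH, with stated times of 10 min and 30 min; on this read-out higher numbers stand for fast clearance and lower numbers for slow clearance. Compound 1 cannot be told apart from the other two, as its steps stay within the scatter: a 1.2-fold lower number from compound 1 to compound 2 (0.06 log units; within the scatter), and a 1.2-fold lower number from compound 1 to compound 3 (0.06 log units; within the scatter). The remaining pair agrees as well, with a 1.0-fold higher number from compound 2 to compound 3 (0.00 log units; within the scatter).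

The unmeasured compound 4 `N#Cc1ccc2c(c1)CN(c1cccnc1)C2=O` keeps the core of compound 1 and changes one group: cyano in place of chloro on an aromatic carbon. In words, this is cyano in place of chloro on an aromatic carbon. Going by the values given here, no measured step touches such a carbon, since all three changes lie on saturated carbons. They bear on the question only indirectly, showing how little the number moved across these compounds. The data therefore favour no direction, and no step beyond the scatter is expected in this assay, though the range must stay wide. The estimate corresponds to an expected step of a 1.2-fold lower number from compound 1 to compound 4 (0.07 log units; within the scatter). Compound 4 is expected at about 65 mL/min/kg, with an estimated range of 35 mL/min/kg to 105 mL/min/kg.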

Compound 4, clearance in the Mus musculus assay: 45.6 mL/min/kg
Estimate against measurement, compound 4: 1.4-fold (0.15 log units) above, and the stated range covers the measured number.
By their numbers in the Mus musculus assay, from the lowest: compounds 4, 2, 3 and 1 (each within the scatter of the next).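

Going by these compounds alone, this is the first change on the aromatic carbon of the shared core, and in the Mus musculus assay cyano in place of chloro gives a 1.7-fold lower number from compound 1 to compound 4 (0.22 log units; within the scatter). So this position, like the saturated ring carbon before it, has not yet produced a clearance step that stands clear of the usual scatter. The same swap does move another measurement well beyond the scatter, showing in this one pair that a large shift towards the polar side need not bring a clear step in clearance, as a physicochemical assay for lipophilicity, measured as octanol-water partition (a lower number here means a more polar compound, a higher number a more lipophilic compound), records: the measured distribution coefficient of compound 1, 2.52, and of compound 4, 1.35, a number 1.17 log units lower (beyond the scatter) In the physicochemical assay compound 1 gives 2.52 and compound 4 gives 1.35 on this read-out.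

Going by these compounds, whether an amine or a carboxylic acid on this aromatic carbon would take clearance beyond the scatter remains open. Also open, on these data alone, is whether cyano in place of chloro would give the same result on the methyl and ethyl compounds, compound 3 and compound 2.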